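Swapping diethylamino for morpholin-4-yl on a carbonyl carbon

This account rests on a few compounds, and the source may have more. Where it says the series, first, only, none or still open, it means among the compounds named here.

- Compound 1 `CNC(=O)NCc1nc(-c2ccc(OC)cc2)c(-c2ccc(OC)cc2)s1`: 15 uM
- Compound 2 `CCN(CC)C(=O)c1nc(-c2ccc(OC)cc2)c(-c2ccc(OC)cc2)s1`: 14 uM

Within the data shown here, in a functional assay (aorta) with Rattus norvegicus as the target (a higher number here means that more compound is needed for the effect, a lower number that less compound is needed), only two numbers exist, and compound 2, at 14 uM, cannot be told apart from its single neighbour: a 1.1-fold lower number from compound 1 to compound 2 (0.03 log units; within the scatter). Compound 3 `COc1ccc(-c2nc(C(=O)N3CCOCC3)sc2-c2ccc(OC)cc2)cc1` keeps the shared core and changes one group: morpholin-4-yl in place of diethylamino on a carbonyl carbon. Among the measured compounds shown here, the one measured step replaced a different pair of groups, so it is only a loose guide, and it gives no sign of a large move. No shift beyond the scatter is expected, in either direction, and the estimated step is no change at the digits printed from compound 2 to compound 3 (within the scatter). For compound 3 the expected value is 14 uM, with an estimated range of 5 uM to 40 uM.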

Compound 3, concentration for half-maximal effect: < 100 uM
Compound 3: a limit, no number (the forecaster's own chance of this, stated with the estimate: 15%); the middle value lies beyond the limit too.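

Compound 3 gives < 100 uM as a limit, not a number. Its steps from compound 1 and compound 2 therefore cannot be read. As far as these compounds go, whether morpholin-4-yl in place of diethylamino on a carbonyl carbon changes the needed concentration at all stays open.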